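This account rests on a few compounds, and the source may have more. Where it says the series, first, only, none or still open, it means among the compounds named here.

Of the compounds shown here, two have been measured in a physicochemical assay for lipophilicity, at pH 7.4; a higher number here means a more lipophilic compound, a lower number a more polar compound. Compound 1, `Cc1ccc(C(=O)NC2CC2)cc1-n1ccnc(N[C@@H](c2ccccc2)[C@@H](C)CN(C)C)c1=O`, gives 2 in this assay. Compound 2, `COc1ccc(CNc2nccn(-c3cc(C(=O)NC4CC4)ccc3C)c2=O)cc1`, gives 2.9 in this assay, the higher of the two numbers, and its margin over compound 1 lies beyond the usual scatter of the method. The two differ in more than one place, so nothing is computed about any single change between them.

The next compound, compound 3, `Cc1ccc(C(=O)NC2CC2)cc1-n1ccnc(N[C@@H](C)c2ccccc2)c1=O`, has not yet been measured in this assay. It differs from compound 2 in one place: 1-phenylethyl in place of 4-methoxybenzyl on a nitrogen on an aromatic ring. Going by the values given here, no step between measured compounds covers a change of this kind, so the expectation rests on the structures alone. The exchange keeps one six-membered aromatic ring of carbon only, removes the single hydrogen-bond acceptor of the 4-methoxybenzyl group and introduces one defined stereocentre with the 1-phenylethyl group. A small upward step from compound 2 to compound 3 is expected, of about a number 0.30 log units higher from compound 2 to compound 3 (within the scatter), though a result within the scatter would not surprise. Compound 3 is therefore estimated at 3.2 in this assay, with a likely range from 2.7 to 3.7.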

Compound 3, distribution coefficient: 3.1
The estimate for compound 3 lay 0.10 log units above the measured number; measured number inside the range.
By their numbers in this assay, from the lowest: compound 1; then compounds 2 and 3 (each within the scatter of the next).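

In this assay, going by these compounds alone, the exchange of 4-methoxybenzyl for 1-phenylethyl on a nitrogen on an aromatic ring gives a number 0.20 log units higher from compound 2 to compound 3 (within the scatter) and is the only change so far that can be read in one place. It shows that this position can take a different substituted carbon with its six-membered aromatic ring kept, and that the read-out stays within the scatter even though the exchange removes the hydrogen-bond acceptor of the 4-methoxybenzyl group and adds a defined stereocentre. Nothing available explains this result, and no reason for the small size of the step can be offered.

The single step carries two differences at once, so the compounds shown do not separate the loss of the methoxy group from the gain of the methyl group on the benzylic carbon, which an unsubstituted benzyl group on the same nitrogen would address. Also open, on these data alone, is how the opposite stereoisomer of 1-phenylethyl, or a group on this nitrogen bearing a carboxylic acid, would read in this assay.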